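Methoxy in Place of Ethyl on the Aromatic Ring

The source may report more compounds than this note shows. Statements on the series, on what has been measured and on what is new or still open speak of the compounds shown alone.

Compound 2 `CCc1cccc(C2=CCN(C(=O)[C@H]3NCC4(CC4)C[C@@H]3C(=O)NO)CC2)c1` and compound 1 `Cc1cccc(C2=CCN(C(=O)[C@H]3NCC4(CC4)C[C@@H]3C(=O)NO)CC2)c1` share one core and differ only on the aromatic ring. In an assay on isolated protein for binding affinity to matrix metalloproteinase-9 (Homo sapiens) (on this read-out lower numbers stand for stronger inhibition and higher numbers for weaker inhibition), compound 1 gives 111 nM, and compound 2 gives 190 nM; the step of a 1.7-fold higher number from compound 1 to compound 2 (0.23 log units; within the scatter) leaves the two numbers within the scatter of each other. Compound 3 `COc1cccc(C2=CCN(C(=O)[C@H]3NCC4(CC4)C[C@@H]3C(=O)NO)CC2)c1` shows methoxy in place of ethyl on an aromatic carbon relative to compound 2. Among the measured compounds shown here, only that single measured step bears on this change, and it was small, so no shift beyond the scatter is expected for compound 3, an expected step of a 1.4-fold lower number from compound 2 to compound 3 (0.13 log units; within the scatter) in this assay. Compound 3 is therefore estimated at 140 nM, within a range from 50 nM to 400 nM.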

Compound 3, half-maximal inhibitory concentration: 110 nM
Compound 3: middle estimate off by 1.3-fold (0.10 log units), on the high side; the range from low to high includes it.
By their numbers in this assay, from the lowest: compounds 3, 1 and 2 (each within the scatter of the next).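

At this aromatic carbon, meta to a large group, the change to methoxy brings a hydrogen-bond acceptor that neither ethyl nor methyl carries, yet in this assay the numbers stay within the scatter, both against ethyl (a 1.7-fold lower number from compound 2 to compound 3 (0.24 log units; within the scatter)) and against methyl (a 1.0-fold lower number from compound 1 to compound 3 (0.00 log units; within the scatter)). Methyl, ethyl and methoxy therefore cannot be told apart at this position in this assay. No evidence is available to explain this result. On these data alone, whether a carboxylic acid, an amine or a longer chain at this carbon would give a step beyond the scatter remains open.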